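This account rests on a few compounds, and the source may have more. Where it says the series, first, only, none or still open, it means among the compounds named here.

Of the compounds shown here, three that share a core have been measured in a functional assay on SK-BR-3 cells (Homo sapiens) for cytotoxicity, read by resazurin assay, with a stated time of 72 h; a higher number here means a weaker inhibitor, a lower number a stronger inhibitor. Compound 1 `O=C(O)CCSC(=S)NCc1cccnc1` gives 7970 nM in this assay, compound 2 `S=C(NCc1cccnc1)SCCc1nc2ccccc2o1` gives 820 nM, and compound 3 `Fc1ccccc1-c1nnc(CCSC(=S)NCc2cccnc2)o1` gives 4690 nM. Among these three numbers compound 3 stands second highest. Its nearest neighbour is compound 1, whose number lies within the usual scatter of that of compound 3, so no order can be read between the two. Compound 2 lies furthest away, with a number lower than that of compound 3 by a margin beyond the scatter.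

Compound 4 `S=C(NCc1cccnc1)SCCc1nnc(-c2cnccn2)o1` has not yet been measured. It differs from compound 3 in one place: pyrazin-2-yl in place of 2-fluorophenyl on an aromatic carbon. Among the compounds with values here, no two measured compounds differ in a single place, so no measured step shows what such an exchange does here. The step that this estimate means, a 1.1-fold higher number from compound 3 to compound 4 (0.03 log units; within the scatter), is expected to be small, in no direction beyond the scatter. Compound 4 is expected to give 5000 nM in this assay, within a range from 1500 nM to 16000 nM.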

Compound 4, half-maximal inhibitory concentration: 1290 nM
Beside the measured number, compound 4's estimate is 3.9-fold (0.59 log units) above it, outside the stated range (below it).
By their numbers in this assay, from the lowest: compounds 2 and 4 (each within the scatter of the next); then compounds 3 and 1 (each within the scatter of the next).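

In this assay, within the data shown here, the exchange of 2-fluorophenyl for pyrazin-2-yl on an aromatic carbon of the five-membered aromatic ring with 2 nitrogen and 1 oxygen brings a 3.6-fold lower number from compound 3 to compound 4 (0.56 log units; beyond the scatter) and gives the first reading of a single change in this set. Among these compounds, it shows that the group at this position can move the number beyond the scatter, which the earlier compounds could not show, as no two of them differed in one place. The entering ring has 2 nitrogen and 2 hydrogen-bond acceptors and the leaving ring has carbon only and a fluorine, but no measurement at hand explains the step.

Which of these differences matters stays open, and phenyl without fluorine or pyridin-2-yl at this position would separate them. Also open, going by these compounds, is how an amine or a carboxylic acid on that ring would read.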